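Two Amide Series Tested for Antiproliferative Activity

This account rests on a few compounds, and the source may have more. Where it says the series, first, only, none or still open, it means among the compounds named here.

Compound 1 `CC(=O)Oc1ccc(C(=O)Nc2cc3ccc(Oc4ccc(C(C)(C)C)cc4)c(C)c3oc2=O)cc1CC=C(C)C` is the only one of the three measured compounds to give a number in a functional assay on SK-BR-3 cells (Homo sapiens) for antiproliferative activity; a lower number here means a stronger inhibitor, a higher number a weaker inhibitor: compound 1 gives 72400 nM. Compound 3 `COc1ccc(Nc2ccc3cc(NC(=O)c4ccc(OC(C)=O)c(CC=C(C)C)c4)c(=O)oc3c2C)cc1` was recorded only as a limit of the assay, > 100000 nM. The change (4-methoxyphenyl)amino in place of 4-(tert-butyl)phenoxy on an aromatic carbon thus produced an at least 1.3-fold higher number from compound 1 to compound 3 (0.14 log units; that floor lies within the scatter). Compound 2 `COc1cccc(-c2cc(C(=O)Nc3cc4ccc(Oc5ccc(C(C)(C)C)cc5)c(C)c4oc3=O)ccc2OC)c1` differs from compound 1 in more than one place; the difference between the two cores is not broken down here. Compound 2 likewise reached only the limit in this assay, > 100000 nM. Taken together, (the limit of > 100000 nM in this assay, at which 2 of the 3 values shown sit). Compound 4 `COc1ccc(Nc2ccc3cc(NC(=O)c4ccc(OC)c(-c5cccc(OC)c5)c4)c(=O)oc3c2C)cc1` is the compound not yet measured; it arises from compound 2 by the same change, ((4-methoxyphenyl)amino in place of 4-(tert-butyl)phenoxy on an aromatic carbon), made at a place described in the same words as before. The earlier change gave an at least 1.3-fold higher number from compound 1 to compound 3 (0.14 log units; that floor lies within the scatter), and compound 4 is therefore expected to remain at the limit as well, a step that the limit leaves unreadable from compound 2 to compound 4. The value expected for compound 4 in this assay is 150000 nM, with a range from 70000 nM to 400000 nM.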

Compound 4, half-maximal inhibitory concentration: > 100000 nM
Compound 4 was reported as a limit; the forecaster's own chance of this, stated with the estimate: 85%; the middle value lies beyond the limit too.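

In this assay compound 4 gives > 100000 nM, a limit of the assay and not a number. Compound 2 also stands at a limit, so no step can be read between compound 2 and compound 4: the limit of > 100000 nM in this assay, at which 3 of the 4 values shown sit. The compounds shown leave open how much (4-methoxyphenyl)amino in place of 4-(tert-butyl)phenoxy changes activity in this pair.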